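Swapping the sulfonyl aryl group on an insulin-degrading enzyme activator

The compounds below may be only part of what the source reports. "The series", "measured", "known", "first", "only" and "open" are said of these compounds alone.

Compound 1: `O=C(CCCc1cn(S(=O)(=O)c2ccccc2)c2ccccc12)NCCCn1ccnc1`, 13200 nM
Compound 2: `O=C(CCCc1cn(S(=O)(=O)c2cccc(F)c2)c2ccccc12)NCCCn1ccnc1`, 10200 nM
Compound 3: `O=C(CCCc1cn(S(=O)(=O)c2ccsc2)c2ccccc12)NCCCn1ccnc1`, 13800 nM

In an assay on isolated protein for activation of Insulin-degrading enzyme (Homo sapiens), read by fluorescence, with stated times of 10 min and 20 min (on this read-out higher numbers stand for an effect only at larger amounts of compound and lower numbers for an effect already at smaller amounts), compound 3 gives 13800 nM, which lies within the scatter of both earlier numbers: a 1.0-fold higher number from compound 1 to compound 3 (0.02 log units; within the scatter) and a 1.4-fold higher number from compound 2 to compound 3 (0.13 log units; within the scatter). Within the data shown here, the only other step, a 1.3-fold lower number from compound 1 to compound 2 (0.11 log units; within the scatter), also stays within the scatter. Compound 4, `Cn1cnc(S(=O)(=O)n2cc(CCCC(=O)NCCCn3ccnc3)c3ccccc32)c1`, differs from compound 3 by 1-methyl-1H-imidazol-4-yl in place of thiophen-3-yl on a sulfonyl sulfur. All three measured steps touch the same sulfonyl aryl group and none moved the read-out beyond the scatter, so no step beyond the scatter is expected here either, in this assay. Compound 4 is therefore expected at about 14000 nM, within 6000 nM to 35000 nM, a step of a 1.0-fold higher number from compound 3 to compound 4 (0.01 log units; within the scatter).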

Compound 4, half-maximal effective concentration: 28800 nM
For compound 4 the middle estimate is 2.1-fold (0.31 log units) below the measured one; the range from low to high includes it.
By their numbers in this assay, from the lowest: compounds 2, 1 and 3 (each within the scatter of the next); then compound 4.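

In this assay this sulfonyl position turns out not to accept every aromatic ring equally: 1-methyl-1H-imidazol-4-yl is the first group shown to move the number beyond the scatter, with a 2.1-fold higher number from compound 3 to compound 4 (0.32 log units; beyond the scatter), a 2.2-fold higher number from compound 1 to compound 4 (0.34 log units; beyond the scatter) and a 2.8-fold higher number from compound 2 to compound 4 (0.45 log units; beyond the scatter). All three steps are modest and point the same way, so more of compound 4 is needed for the effect than of any earlier compound. Nothing measured here explains this rise. On these data alone, whether the methyl or the second ring nitrogen of the imidazole matters more remains open. So does the effect of a pyridine ring, or of a phenyl ring carrying a carboxylic acid, on this sulfonyl sulfur.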